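Lengthening the side chain of compound 3

This account rests on a few compounds, and the source may have more. Where it says the series, first, only, none or still open, it means among the compounds named here.

Among the compounds with values here, in a functional assay on HCT-116 cells (Homo sapiens) for cytotoxicity, read by MTT assay, with a stated time of 72 h (on this read-out higher numbers stand for weaker inhibition and lower numbers for stronger inhibition), compound 3 `O=C1c2c[n+]([O-])c3ccccc3c2C(=O)c2c1c1ccccc1n2CCN1CCCCC1` gives 780 nM and sits in the middle of the three numbers so far. Compound 1 `O=C1c2c[n+]([O-])c3ccccc3c2C(=O)c2c1c1ccccc1n2CCN1CCCC1` gives 270 nM and compound 2 `CCCCN1CCN(CCCCn2c3c(c4ccccc42)C(=O)c2c[n+]([O-])c4ccccc4c2C3=O)CC1` gives 1920 nM at the high end. Compound 4 `CN1CCN(CCCCCn2c3c(c4ccccc42)C(=O)c2c[n+]([O-])c4ccccc4c2C3=O)CC1` has 3-(4-methylpiperazin-1-yl)propyl in place of piperidin-1-yl on a saturated chain carbon, two bonds along the chain from an aromatic nitrogen. The closest guide is a similar swap, a 2.5-fold lower number from compound 2 to compound 3 (0.39 log units; beyond the scatter) and it is modest. The step of a 7.1-fold higher number from compound 1 to compound 2 (0.85 log units; beyond the scatter) also points to a higher number with a piperazine-bearing group. A modest rise is therefore expected in this assay and the expected step is a 2.2-fold higher number from compound 3 to compound 4 (0.34 log units; beyond the scatter) as an estimate. Compound 4 is estimated at 1700 nM (expected range 600 nM to 4800 nM).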

Compound 4, half-maximal inhibitory concentration: 1220 nM
The estimate for compound 4 lay 1.4-fold (0.14 log units) above the measured number; measured number inside the range.
By their numbers in this assay, from the lowest: compound 1; then compounds 3, 4 and 2 (each within the scatter of the next, the first and the last beyond it).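

In this assay, a longer chain ending in a methylpiperazine stays within the scatter of the shorter piperidin-1-yl compound (a 1.6-fold higher number from compound 3 to compound 4 (0.19 log units; within the scatter)) and of the butylpiperazine compound (a 1.6-fold lower number from compound 2 to compound 4 (0.20 log units; within the scatter)). Only the pyrrolidin-1-yl compound stands clearly apart (a 4.5-fold higher number from compound 1 to compound 4 (0.65 log units; beyond the scatter)), so at this position, adding a piperazine-bearing chain to the piperidin-1-yl compound's length need not shift the number beyond the scatter. On these data alone, whether a morpholine ring or a primary amine at the chain end would match compound 1 or compound 4 remains open. Nothing given here explains these differences.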